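Working notes: from compound 1 to compound 3

The source may hold more compounds than are shown below. What is called first, only, known or untested is meant among the compounds shown, and "the series" means these compounds.

Measured so far in an ADME assay on BMEC cells (Bos taurus) for cytotoxicity, read by sulforhodamine B assay; on this read-out higher numbers stand for weaker inhibition and lower numbers for stronger inhibition:
- compound 1 `COc1ccc(/C=C/c2cc(OC)c3ccoc3c2)cc1O`: > 10000 nM (a limit)
- compound 2 `COc1cc(/C=C\c2cc(O)c3ccsc3c2)cc(OC)c1`: 110 nM

Compound 1 stands at a limit and not at a number: > 10000 nM. As far as these compounds go, its true position in this assay therefore stays open. The next compound to be read is compound 3 `COc1ccc(/C=C\c2cc(OC)c3ccoc3c2)cc1O`. The change is the two compounds have the same atoms and bonds and differ only in configuration as drawn: 1 of 1 stereo elements differ; a double bond is drawn E in compound 1 and Z in compound 3: the two compounds have the same atoms and bonds, and a double bond is drawn E in compound 1 and Z in compound 3. Among the compounds with values here, no measured pair yet shows the size of such a change. Compound 2, with its double bond drawn Z, gives 110 nM, and on that value a large move towards stronger inhibition is expected for compound 3. The expected size of this move is an at least 66-fold lower number from compound 1 to compound 3 (1.82 log units; beyond the scatter). Compound 3 is estimated at 150 nM, with an expected range from 15 nM to 3000 nM.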

Compound 3, half-maximal inhibitory concentration: 35 nM
For compound 3 the middle estimate is 4.3-fold (0.63 log units) above the measured one; the range from low to high includes it.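

In this assay, within the data shown here, the configuration of the double bond is now tied to a measured step for the first time: redrawing it from E to Z gives an at least 280-fold lower number from compound 1 to compound 3 (2.45 log units; beyond the scatter) with nothing else changed. As far as these compounds go, that step has a floor and no upper end, and its true size stays open: the limit of > 10000 nM in this assay, at which 1 of the 3 values shown sits. Within this pair, the configuration of the double bond is the only possible source of the step: the fact that compounds 1 and 3 differ only in the configuration as drawn.

Among these compounds, whether the same change carries the same weight on other members stays open, as only this one pair isolates it. The compounds shown also leave open how an amine or a carboxylic acid in place of the hydroxyl would read in this assay on the Z compound.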